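Acetylation of a free hydroxyl in a diterpenoid lactone series

The source may report more compounds than this note shows. Statements on the series, on what has been measured and on what is new or still open speak of the compounds shown alone.

Compound 1 `C=C1CC[C@@H]2[C@](C)(CO)[C@H](OC(C)=O)CC[C@@]2(C)[C@@H]1C/C=C1/C(=O)OC[C@H]1O` bears two free hydroxyls; in a functional assay on KB cells (Homo sapiens) for cytotoxicity, read by sulforhodamine B assay (on this read-out higher numbers stand for an effect only at larger amounts of compound and lower numbers for an effect already at smaller amounts), compound 1 gives 35.7 uM. Compound 2 `C=C1CC[C@@H]2[C@](C)(CO)[C@H](OC(C)=O)CC[C@@]2(C)[C@@H]1C/C=C1/C(=O)OC[C@H]1OC(C)=O` carries the change (acetyl in place of hydrogen on an oxygen on a saturated carbon), and in this assay compound 2 gives 11.7 uM. The resulting step, a 3.1-fold lower number from compound 1 to compound 2 (0.48 log units; beyond the scatter), stands beyond the scatter. Compound 3 `C=C1CC[C@@H]2[C@](C)(COC(C)=O)[C@H](O)CC[C@@]2(C)[C@@H]1C/C=C1/C(=O)OC[C@H]1O` holds the same atoms as compound 1 joined differently; how the cores of compound 1 and compound 3 differ is not broken down here. In this assay compound 3 gives 15.3 uM, close to compound 2 and beyond the scatter from compound 1.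

Compound 4 `C=C1CC[C@@H]2[C@](C)(COC(C)=O)[C@H](O)CC[C@@]2(C)[C@@H]1C/C=C1/C(=O)OC[C@H]1OC(C)=O` is the not yet measured partner of compound 3, differing by acetyl in place of hydrogen on an oxygen on a saturated carbon. The place is described in the same words for both pairs, so this is the same change as that between compound 1 and compound 2, which occurs twice among the compounds shown. Resting on that single step, a 3.1-fold lower number from compound 1 to compound 2 (0.48 log units; beyond the scatter), the expected step is a 2.8-fold lower number from compound 3 to compound 4 (0.44 log units; beyond the scatter). In this assay, among the measured compounds shown here, compound 4 is therefore estimated at 5.5 uM, between 2.5 uM and 12 uM, with only one prior example to support it.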

Compound 4, concentration for half-maximal effect: 26.4 uM
For compound 4 the middle estimate is 4.8-fold (0.68 log units) below the measured one, outside the stated range (above it).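

In this assay, acetyl in place of hydrogen on an oxygen on a saturated carbon does not transfer as a fixed step from the core of compound 1 to the core of compound 3, and the two steps differ: the same change on two cores in this assay, a 3.1-fold lower number (0.48 log units; beyond the scatter) from compound 1 to compound 2 and a 1.7-fold higher number (0.24 log units; within the scatter) from compound 3 to compound 4, 5.3-fold (0.72 log units) apart, beyond the scatter of two such steps. On the core of compound 3, the step, a 1.7-fold higher number from compound 3 to compound 4 (0.24 log units; within the scatter), gives no readable effect of the acetyl group, so the hydroxy to acetoxy change cannot be treated as a general route to lower numbers in this series. With a single pair on each core, these data show that the step depends on the core in this comparison, but they do not show why, nor which of the two steps is more typical.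

The compounds shown leave open whether the dependence on the core extends to other groups on this oxygen, such as a longer acyl chain like butanoyl. They also leave open how an amine in place of this hydroxyl would behave on either core.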